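Methyl shifts on the thiourea-bearing ring and lipophilicity

The source may report more compounds than this note shows. Statements on the series, on what has been measured and on what is new or still open speak of the compounds shown alone.

Measured compounds:
Compound 1 `Cc1ccc(NC(=S)NC(=O)Nc2ccc3c(c2)C(=O)C(=O)N3Cc2ccccc2)cc1`: 2.96
Compound 2 `Cc1cccc(NC(=S)NC(=O)Nc2ccc3c(c2)C(=O)C(=O)N3Cc2ccccc2Cl)c1`: 3.72

Among the compounds with values here, in a physicochemical assay for lipophilicity, in phosphate buffer, measured as octanol-water partition (on this read-out lower numbers stand for lower lipophilicity and higher numbers for higher lipophilicity), compound 2 gives 3.72, the higher of the two numbers known so far. Its nearest neighbour, compound 1, gives 2.96 in this assay, a gap that lies beyond the usual scatter of this measurement; the two compounds differ in more than one place, so no single change can be tied to that gap.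

Compound 3 `Cc1ccc(NC(=S)NC(=O)Nc2ccc3c(c2)C(=O)C(=O)N3Cc2ccccc2Cl)cc1` has not yet been measured. It differs from compound 2 by one change: 4-methylphenyl in place of 3-methylphenyl on an amide-type nitrogen. The same atoms are present, only joined differently, so a small step is expected in this assay, likely within the scatter and in no particular direction. Compound 3 is therefore expected to give 3.7, with a range from 3.3 to 4.1; the expected step from compound 2 to compound 3 is a number 0.02 log units lower from compound 2 to compound 3 (within the scatter).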

Compound 3, partition coefficient: 3.73
Compound 3: the middle estimate sits 0.03 log units below what was measured, and the stated range covers the measured number.
By their numbers in this assay, from the lowest: compound 1; then compounds 2 and 3 (each within the scatter of the next).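

In this assay, 4-methylphenyl in place of 3-methylphenyl on an amide-type nitrogen gives a number 0.01 log units higher from compound 2 to compound 3 (within the scatter), so the two methyl placements cannot be told apart on this read-out, at least with this core. Chloro in place of hydrogen on an aromatic carbon gives a number 0.77 log units higher from compound 1 to compound 3 (beyond the scatter), which ties a gap of this size to a single change, something the earlier pair, differing in more than one place, could not do. Nothing among the data shown offers a reason for either step. 

From the compounds shown here alone, it remains open whether an amine or a methoxy group in place of the methyl would also leave the number within the scatter. Also open, going by these compounds, is whether fluoro or bromo in place of the chloro would give a step of similar size.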